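A Trifluoromethyl Variant of the Fluorosulfonyloxy Lead

This account rests on a few compounds, and the source may have more. Where it says the series, first, only, none or still open, it means among the compounds named here.

Three compounds share one core. In a functional assay (trachea) with Rattus norvegicus as the target (on this read-out lower numbers stand for lower potency and higher numbers for higher potency (the scale is a negative logarithm)), compound 1 `CC1(C)C=C(n2ccccc2=O)c2cc(C(=O)c3ccco3)ccc2O1` gives 5.92, compound 2 `Cc1ccc(C)n1-c1ccc2c(c1)C(n1ccccc1=O)=CC(C)(C)O2` gives 6.78, and compound 3 `CC1(C)C=C(n2ccccc2=O)c2cc(OS(=O)(=O)F)ccc2O1` gives 7.22, the highest of the three, with a number 1.30 log units higher from compound 1 to compound 3 (beyond the scatter) and a number 0.44 log units higher from compound 2 to compound 3 (beyond the scatter) both beyond the scatter. Compound 4 `CC1(C)C=C(n2ccccc2=O)c2cc(C(F)(F)F)ccc2O1` changes this position again: trifluoromethyl in place of (fluorosulfonyl)oxy on an aromatic carbon. Within the data shown here, all three measured steps, a number 0.86 log units higher from compound 1 to compound 2 (beyond the scatter) included, concern substituents carrying hydrogen-bond acceptors at this position, whereas trifluoromethyl carries none, so no step directly matches. Since every exchange so far shifted potency beyond the scatter, a step of a number 0.32 log units lower from compound 3 to compound 4 (beyond the scatter) is expected, most likely a modest loss. Compound 4 is therefore estimated at 6.9, between 6.2 and 7.6.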

Compound 4, logarithm of the reciprocal of the active concentration, log(1/C): 7.37
The estimate for compound 4 lay 0.47 log units below the measured number, within the range that was stated.
By their numbers in this assay, from the lowest: compound 1; then compound 2; then compounds 3 and 4 (each within the scatter of the next).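

Trifluoromethyl carries no hydrogen-bond acceptors, yet replacing (fluorosulfonyl)oxy with it gives a number 0.15 log units higher from compound 3 to compound 4 (within the scatter), so in this pair the acceptors of the leaving group are not required to keep the number at this level. The advantage over the other two groups also holds for trifluoromethyl, with a number 0.59 log units higher from compound 2 to compound 4 (beyond the scatter) and a number 1.45 log units higher from compound 1 to compound 4 (beyond the scatter). No measurement shown explains these results. The compounds shown leave open whether a nitrile, a chlorine atom or an amine on this aromatic carbon would keep the number at this level.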